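An Epimer at the Chain Stereocentre of Compound 3

This account rests on a few compounds, and the source may have more. Where it says the series, first, only, none or still open, it means among the compounds named here.

Compound 3 `CCC(CC)(c1ccc(OC[C@@H](O)CO)c(C)c1)c1ccc(OC[C@@H](O)C(C)(C)OCCCCCCCCO)c(C)c1` has been examined in an assay on HEK293 cells for agonist activity at vitamin D3 receptor (Homo sapiens), read by a beta-galactosidase reporter; a higher number here means that more compound is needed for the effect, a lower number that less compound is needed. In this assay compound 3 reaches only > 3000 nM, which is a limit of the assay and not a number. Among the values shown, compound 2 `CCCCCCOC(C)(C)[C@@H](O)COc1ccc(C(CC)(CC)c2ccc(OC[C@@H](O)CO)c(C)c2)cc1C` in this assay gives 1500 nM, and compound 1 `CCCCCCCCOC(C)(C)[C@@H](O)COc1ccc(C(CC)(CC)c2ccc(OC[C@@H](O)CO)c(C)c2)cc1C` in this assay is reported as "not active" (no number reported), again without a number. Compound 3 thus stands at the limit of > 3000 nM in this assay, at which 1 of the 3 values shown sits, at the weak end of what has been seen.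

Compound 4 `CCC(CC)(c1ccc(OC[C@@H](O)CO)c(C)c1)c1ccc(OC[C@H](O)C(C)(C)OCCCCCCCCO)c(C)c1` is still to be measured in this assay. Compared with compound 3, (the two compounds have the same atoms and bonds and differ only in configuration as drawn: 1 of 2 stereo elements differ; a stereocentre at a saturated chain carbon is drawn R in compound 3 and S in compound 4). Within the data shown here, no measured pair among the three compounds isolates such a change, so the size of the step cannot be read from a comparable case. The account nevertheless expects that inverting this centre moves the value towards more activity by a step somewhat beyond the scatter, with the caution that compound 3 provides only a limit as the starting point. For compound 4 the estimate is 1500 nM, within 400 nM to 6000 nM. This corresponds to an expected step of an at least 2.0-fold lower number from compound 3 to compound 4 (0.30 log units; that floor lies within the scatter).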

Compound 4, half-maximal effective concentration: 1200 nM
The estimate for compound 4 lay 1.3-fold (0.10 log units) above the measured number; measured number inside the range.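

Inverting the chain stereocentre gives an at least 2.5-fold lower number from compound 3 to compound 4 (0.39 log units; beyond the scatter) in this assay, the first sign that the configuration at this position can move the number beyond the scatter. The shift can be assigned to that centre alone because nothing else changes between the two structures: the fact that compounds 3 and 4 differ only in the configuration as drawn Compound 3 marks only a limit of the assay, not a number, so the step has a floor but no measured size: the limit of > 3000 nM in this assay, at which 1 of the 4 values shown sits. The other new comparison, 2-hydroxyethyl in place of hydrogen on a saturated chain carbon, gives a 1.3-fold lower number from compound 2 to compound 4 (0.10 log units; within the scatter), a difference that stays within the scatter, so this chain change shows no clear effect once the stereocentre is drawn as in compound 4.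

On these data alone, how large the stereocentre step really is stays open, as does whether the same inversion would matter to the same degree on a chain without the terminal hydroxyl. As far as these compounds go, it is also open whether a carboxylic acid or an amine at the end of the chain, in place of that hydroxyl, would keep the number where compound 4 puts it.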